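The source may hold more compounds than are shown below. What is called first, only, known or untested is meant among the compounds shown, and "the series" means these compounds.

Measured so far:
compound 1 `N#Cc1c(-c2ccccc2)cn(-c2ccc(S(=O)(=O)Nc3nccs3)cc2)c1N` — 3490 nM
compound 2 `N#Cc1c(-c2ccccc2)cn(-c2ccc(S(=O)(=O)Nc3ccccn3)cc2)c1N` — 4600 nM

In a functional assay on MCF7 cells (Homo sapiens) for inhibition, read by sulforhodamine B assay, with a stated time of 24 h (on this read-out lower numbers stand for stronger inhibition and higher numbers for weaker inhibition), compound 1 stands at the lower of the two numbers, with compound 2 nearest: a 1.3-fold higher number from compound 1 to compound 2 (0.12 log units; within the scatter). The two values are therefore indistinguishable within the usual scatter.

Compound 3 `N#Cc1c(-c2ccccc2)cn(-c2ccc(S(=O)(=O)Nc3nccs3)cc2)c1NC(N)=O` differs from compound 1 in one place: carbamoyl in place of hydrogen on a nitrogen on an aromatic ring.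

Going by the values given here, the only measured step, from compound 1 to compound 2, concerns the group on the sulfonamide nitrogen and lies within the scatter. Among the compounds with values here, no measured pair touches the amino group on the core, so nothing among the numbers indicates either the size or the direction of the step to compound 3 in this assay. From the compounds shown here alone, the working expectation is consequently no step beyond the scatter, carried with a wide range, as the change itself is untested.

Compound 3 is estimated at 3500 nM in this assay, with a range from 1000 nM to 12000 nM. This estimate corresponds to an expected step of a 1.0-fold higher number from compound 1 to compound 3 (0.00 log units; within the scatter).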

Compound 3, half-maximal inhibitory concentration: 8050 nM
Estimate against measurement, compound 3: 2.3-fold (0.36 log units) below; the measured number falls inside the stated range.
By their numbers in this assay, from the lowest: compounds 1, 2 and 3 (each within the scatter of the next, the first and the last beyond it).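

Amino to ureido is the first change at this nitrogen that can be read, and in this assay it gives a 2.3-fold higher number from compound 1 to compound 3 (0.36 log units; beyond the scatter), a modest step toward weaker inhibition. Going by these compounds alone, this position therefore responds to substitution by more than the scatter, unlike the sulfonamide nitrogen, where the only earlier change gave a 1.3-fold higher number from compound 1 to compound 2 (0.12 log units; within the scatter). Nothing available explains the direction or size of this step.

The compounds shown leave open how an acetyl group or a methyl group on this nitrogen would compare with carbamoyl, and so whether the loss is particular to carbamoyl or follows any substitution of the amino hydrogen. From the compounds shown here alone, it also remains open whether the same step holds with pyridin-2-yl on the sulfonamide nitrogen, as it is read here only with 1,3-thiazol-2-yl.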